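Azole variation on the biaryl end of the series

A few compounds are considered here, and "the series" means these few. Any claim that something is new, unique, unknown or untested is made for them only; others in the source may bear on it.

Compound 1 `CCC(C)(C)Cc1c[nH]c(CCc2ccc(-c3cccnc3)cc2)n1`: 7.5 nM in an in vitro assay on CHO cells for displacement of a labelled ligand from Bombesin receptor subtype-3 (Homo sapiens), read by scintillation counting, with a stated time of 2 h; on this read-out higher numbers stand for weaker inhibition and lower numbers for stronger inhibition.
Compound 2 `CCC(C)(C)Cc1c[nH]c(CCc2ccc(-n3ccnn3)cc2)n1`: 390 nM in this assay.

Compound 2 gives the higher of the two numbers; its nearest neighbour is compound 1, and a 52-fold higher number from compound 1 to compound 2 (1.72 log units; beyond the scatter). Compound 3 `CCC(C)(C)Cc1c[nH]c(CCc2ccc(-n3cccn3)cc2)n1` differs from compound 2 in one place: 1H-pyrazol-1-yl in place of 1H-1,2,3-triazol-1-yl on an aromatic carbon. Among the measured compounds shown here, only the step from compound 1 to compound 2 bears on this, and it was large, so the group at this position clearly matters in this assay. Both the leaving and entering groups are five-membered aromatic rings, so a much smaller step is expected, with compound 3 estimated a little lower than compound 2, a 2.6-fold lower number from compound 2 to compound 3 (0.41 log units; beyond the scatter). The estimate for compound 3 is 150 nM, between 40 nM and 600 nM.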

Compound 3, half-maximal inhibitory concentration: 33 nM
The estimate for compound 3 lay 4.5-fold (0.66 log units) above the measured number, and the stated range ends above it.
By their numbers in this assay, from the lowest: compound 1; then compound 3; then compound 2.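

Two five-membered aromatic rings on this aromatic carbon are not interchangeable: in this assay the change gives a 12-fold lower number from compound 2 to compound 3 (1.07 log units; beyond the scatter), a large step although the heavy-atom count stays the same and one ring nitrogen gives way to carbon. The 1H-pyrazol-1-yl group recovers much of the loss seen with the 1H-1,2,3-triazol-1-yl group, yet a modest gap to the pyridin-3-yl group remains, with a 4.4-fold higher number from compound 1 to compound 3 (0.64 log units; beyond the scatter). Nothing on hand accounts for the difference between the two azoles.

On these data alone, it remains open whether 1H-imidazol-1-yl or 1H-1,2,4-triazol-1-yl would sit nearer the pyrazole or the triazole. A plain phenyl ring or a carboxylic acid at this place is also untested among the compounds shown here.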